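Fluorine on the Amide Ring: Cytotoxicity Left Unchanged

The compounds below may be only part of what the source reports. "The series", "measured", "known", "first", "only" and "open" are said of these compounds alone.

Measured compounds:
compound 1 `Cc1cn(C/C=C\CNC(=O)c2ccccc2)c(=O)[nH]c1=O` gives > 100000 nM
compound 2 `Nc1ccn(C/C=C\CNC(=O)c2ccccc2)c(=O)n1` gives > 100000 nM
compound 3 `Cc1cn(C/C=C\CNC(=O)c2ccc(F)cc2)c(=O)[nH]c1=O` gives > 100000 nM

In a functional assay on HEp-2 cells (Homo sapiens) for cytotoxicity, read by MTT assay, with a stated time of 72 h (on this read-out lower numbers stand for stronger inhibition and higher numbers for weaker inhibition), compound 1 reaches only a limit, > 100000 nM. Compound 2 likewise gives only a limit, > 100000 nM. Compound 3 also stops at a limit, > 100000 nM. Compound 3 comes from compound 1 by fluoro in place of hydrogen on an aromatic carbon, and the step that the two limits leave unreadable from compound 1 to compound 3 cannot be read, since (the limit of > 100000 nM in this assay, at which 3 of the 3 values shown sit). The difference between the two cores of compound 1 and compound 2 is not broken down here. Compound 4 `Nc1ccn(C/C=C\CNC(=O)c2ccc(F)cc2)c(=O)n1` comes from compound 2 by fluoro in place of hydrogen on an aromatic carbon, the same change at the same kind of place. The step of a number no higher from compound 2 to compound 4 (the limit leaves the size open) is expected to be unreadable in the same way, because compound 2 sits at > 100000 nM. For compound 4 the estimate is 100000 nM, most likely reported only as a limit.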

Compound 4, half-maximal inhibitory concentration: > 100000 nM
Compound 4 was reported as a limit; the forecaster's own chance of this, stated with the estimate: 85%; the middle value lies on the limit itself.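

No new step can be read from compound 2 to compound 4, because both stop at a limit rather than giving a number: the limit of > 100000 nM in this assay, at which 4 of the 4 values shown sit. The compounds shown leave open how strongly any of them acts in this assay, and whether going from phenyl to 4-fluorophenyl changes that at all.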